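A few compounds are considered here, and "the series" means these few. Any claim that something is new, unique, unknown or untested is made for them only; others in the source may bear on it.

Compound 1 `O=C(CCc1ccccc1-c1cccc(CSCCc2ccccc2)c1)NS(=O)(=O)c1cccs1` gives 2000 nM in an assay on isolated protein for binding affinity to prostaglandin E2 receptor EP2 subtype (Homo sapiens); a lower number here means a stronger inhibitor, a higher number a weaker inhibitor. Compound 2 `O=C(CCc1ccccc1-c1ccc(OCCCOc2cccc(CSCCc3ccccc3)c2)cc1)NS(=O)(=O)c1cccs1` gives 4900 nM in this assay, and compound 3 `Cc1cccc(OCCCOc2ccc(-c3ccccc3CCC(=O)NS(=O)(=O)c3cccs3)cc2)c1` gives 2900 nM. Compound 3 thus stands second highest of the three numbers, with compound 1 nearest and compound 2 furthest, yet both gaps lie within the scatter. Going by the values given here, the one single-point step measured so far, a 1.7-fold lower number from compound 2 to compound 3 (0.23 log units; within the scatter), concerns a hydrogen in place of phenethylsulfanyl on a saturated chain carbon bound to an aromatic carbon, a change at a different place than the one now considered.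

Compound 4 `Cc1cccc(OCCCOc2ccc(-c3ccccc3CC(C)C(=O)NS(=O)(=O)c3cccs3)cc2)c1` differs from compound 3 by methyl in place of hydrogen on a saturated chain carbon bound to a carbonyl carbon and a saturated chain carbon. Among the compounds with values here, no measured pair shows a methyl entering at a saturated chain carbon bound to a carbonyl carbon and a saturated chain carbon, so nothing in the data directly bears on this step. For compound 4 the expectation is therefore a step of a 1.0-fold higher number from compound 3 to compound 4 (0.01 log units; within the scatter), that is, no change beyond the scatter. Compound 4 is accordingly estimated at 3000 nM, within a range from 1400 nM to 6500 nM.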

Compound 4, inhibition constant: 2900 nM
For compound 4 the middle estimate is 1.0-fold (0.01 log units) above the measured one; measured number inside the range.
By their numbers in this assay, from the lowest: compounds 1, 3, 4 and 2 (each within the scatter of the next, the first and the last beyond it).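

In this assay, methyl in place of hydrogen on a saturated chain carbon bound to a carbonyl carbon and a saturated chain carbon gives no change at the digits printed from compound 3 to compound 4 (within the scatter), so this position now has a measured step, which compounds 1, 2 and 3 could not provide. The added carbon therefore leaves the binding number of this compound pair unmoved, at least for methyl on the core of compound 3. Nothing shown here accounts for this result.

The compounds shown leave open whether an ethyl, a second methyl, a hydroxyl or an amine on the same carbon would also leave the number unmoved. They also leave open whether methyl at this carbon would give the same result on the cores of compound 1 and compound 2.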